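The compounds below may be only part of what the source reports. "The series", "measured", "known", "first", "only" and "open" are said of these compounds alone.

Measured so far:
- compound 1, `COc1ccc(CNc2nc([Se]C)nc3ccccc23)cc1`: 98600 nM
- compound 2, `CSc1nc(NCc2ccccc2)c2ccccc2n1`: 82800 nM

Both compounds were tested in a functional assay on MCF7 cells (Homo sapiens) for cytotoxicity, read by MTT assay, with a stated time of 72 h; on this read-out lower numbers stand for stronger inhibition of growth and higher numbers for weaker inhibition of growth. Compound 2 gives 82800 nM, the lower of the two numbers, and compound 1 gives 98600 nM, a gap that lies within the usual scatter of this kind of measurement, so the two cannot be told apart on these numbers.

The next compound, compound 3, `COc1ccc(CNc2nc(SC)nc3ccccc23)cc1`, has not yet been measured. It differs from compound 2 in one place: methoxy in place of hydrogen on an aromatic carbon. Going by the values given here, no measured pair shows this change on its own, so there is nothing to set its size directly. What can be said is that compound 1 also carries a methoxy group and its number in this assay sits within the scatter of compound 2. On that basis compound 3 is expected to land close to compound 2, with a step from compound 2 to compound 3 of about a 1.1-fold higher number from compound 2 to compound 3 (0.04 log units; within the scatter), which is no more than the scatter. The estimate for compound 3 is 90000 nM, with a range from 40000 nM to 200000 nM.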

Compound 3, concentration for total growth inhibition: 85100 nM
Beside the measured number, compound 3's estimate is 1.1-fold (0.02 log units) above it; the measured number falls inside the stated range.
By their numbers in this assay, from the lowest: compounds 2, 3 and 1 (each within the scatter of the next).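

Methoxy in place of hydrogen on an aromatic carbon, para to a large group, can now be read as a single change: in this assay it gives a 1.0-fold higher number from compound 2 to compound 3 (0.01 log units; within the scatter), so at this position on the six-membered ring, adding methoxy to compound 2 produces no difference that can be told from the scatter. Compound 3 also gives the first direct view of sulfur against selenium in the group of two heavy atoms on the aromatic carbon, and putting the group with sulfur in place of the group with selenium gives a 1.2-fold lower number from compound 1 to compound 3 (0.06 log units; within the scatter), so this exchange also stays within the scatter. Nothing here bears on why neither change shifts the number.

The compounds shown leave open whether a different group at the methoxy position, such as an amine or a carboxylic acid, would move the number beyond the scatter. They also leave open whether a longer chain in place of the carbon of the sulfur group would do so.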